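The source may report more compounds than this note shows. Statements on the series, on what has been measured and on what is new or still open speak of the compounds shown alone.

Measured so far, in a functional assay on the whole organism (Tail, strain ICR) with Mus musculus as the target, in the tail flick test, with a stated time of 60 min, at a dose of 25 umol/kg by the oral route; a higher number here means a stronger effect of the compound at the dose given, a lower number a weaker effect:
- compound 1 `N=C(N)NCCC[C@H](NC(=O)CN(c1nc(Cl)nc2[nH]cnc12)C1CC1)C(=O)O` gives 51%
- compound 2 `N=C(N)NCCC[C@H](NC(=O)CN(c1nc(Cl)nc2[nH]cnc12)C1CC1)C(=O)OCc1ccccc1` gives 30.6%
- compound 3 `CSCC[C@H](NC(=O)CN(c1nc(Cl)nc2[nH]cnc12)C1CC1)C(=O)OCc1ccccc1` gives 30.8%

Compound 1 holds the highest number of the three. Its nearest neighbour is compound 3, and both compound 3 and compound 2 lie beyond the scatter below it. Going by the values given here, the only change to the oxygen next to the carbonyl is a number 20.4 percentage points lower from compound 1 to compound 2 (beyond the scatter), a modest loss.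

The unmeasured compound 4 `NC(=O)CC[C@H](NC(=O)CN(c1nc(Cl)nc2[nH]cnc12)C1CC1)C(=O)O` differs from compound 1 by a group of 3 heavy atoms (1 carbon, 1 nitrogen, 1 oxygen; no ring) in place of a group of 5 heavy atoms (2 carbon, 3 nitrogen; no ring), on a saturated chain carbon, three bonds along the chain from an amide-type nitrogen and a carbonyl carbon. The measured step that bears on this is the swap at the same chain carbon between compound 2 and compound 3, where a number 0.2 percentage points higher from compound 2 to compound 3 (within the scatter), that is, no change beyond the scatter, although there the group that entered was different and the exchange was made on the benzyl ester rather than on compound 1 itself. The step from compound 1 to compound 2 does not touch this position and gives no direct guide. Among the compounds with values here, on this basis no step beyond the scatter is expected in this assay, with a slight lean downward, since the one comparable exchange left the number flat and no step in the set moved upward.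

Compound 4 is therefore estimated at 45%, within 25% to 62%. This estimate implies a number 6 percentage points lower from compound 1 to compound 4 (within the scatter).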

Compound 4, a percentage reported as activity, at one dose (the size of the read-out at that dose, not a potency): 38.4%
Beside the measured number, compound 4's estimate is 6.6 percentage points above it, and the stated range covers the measured number.
By their numbers in this assay, from the lowest: compounds 2, 3 and 4 (each within the scatter of the next); then compound 1.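

On the free acid, the carbamoyl group at the saturated chain carbon, three bonds along the chain from an amide-type nitrogen and a carbonyl carbon, gives a step beyond the scatter in this assay: a number 12.6 percentage points lower from compound 1 to compound 4 (beyond the scatter). The earlier exchange at this same carbon, on the benzyl ester, stayed within the scatter, a number 0.2 percentage points higher from compound 2 to compound 3 (within the scatter), so this position is not silent in every compound, although the entering group and the ester both differ between the two exchanges. Both one-place changes shown from compound 1, this one and the ester change with a number 20.4 percentage points lower from compound 1 to compound 2 (beyond the scatter), lower the number, and no measurement shown here bears on why the carbamoyl exchange has this effect.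

From the compounds shown here alone, whether the size of the step depends on the carbamoyl group itself or on the free acid remains open, and the carbamoyl group on the benzyl ester, together with the group of 1 carbon and 1 sulfur on the free acid, would separate the two. Also open, going by these compounds, is how an amine, a carboxylic acid or a longer chain at this carbon would read in this assay on the free acid.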